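The compounds below may be only part of what the source reports. "The series", "measured", "known", "first", "only" and "open" are said of these compounds alone.

Measured compounds:
- compound 1 `FC(F)(F)c1ccc(Nc2ncnc3sc(Nc4c(Cl)cccc4Cl)nc23)cc1`: 3 nM
- compound 2 `CSc1ccccc1Nc1nc2c(Nc3ccc(C(F)(F)F)cc3)ncnc2s1`: 26 nM

In a functional assay on HEK293 cells for antagonist activity at transient receptor potential cation channel subfamily V member 1 (Rattus norvegicus), read by calcium flux (on this read-out higher numbers stand for weaker inhibition and lower numbers for stronger inhibition), compound 1 gives 3 nM, the lowest of the two numbers; compound 2 sits an 8.7-fold higher number from compound 1 to compound 2 (0.94 log units; beyond the scatter), a change at a different place than the one studied here. Compound 3 `CN(c1ccc(C(F)(F)F)cc1)c1ncnc2sc(Nc3c(Cl)cccc3Cl)nc12` differs from compound 1 by methyl in place of hydrogen on a nitrogen on an aromatic ring. No measured step touches this nitrogen, so the expectation rests on the change itself rather than on any shown step. A modest weakening, a 5.0-fold higher number from compound 1 to compound 3 (0.70 log units; beyond the scatter), is expected, with a wide range. Compound 3 is therefore estimated at 15 nM, between 3 nM and 80 nM.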

Compound 3, half-maximal inhibitory concentration: > 1000 nM
Compound 3: a limit, no number; the forecaster's own chance of this, stated with the estimate: 5%; at least 66-fold (1.82 log units) between middle value and limit.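

On this nitrogen on an aromatic ring, a methyl of just one heavy atom in place of hydrogen costs a large part of the inhibition in this assay: an at least 330-fold higher number from compound 1 to compound 3 (2.52 log units; beyond the scatter). Among the compounds shown here, the earlier step touched another place, so this is the first sign that the core of compound 1 is sensitive at this nitrogen. Compound 3 gives only a limit, not a number, so the full size of this loss stays unknown: the limit of > 1000 nM in this assay, at which 1 of the 3 values shown sits.

Going by these compounds, whether a group such as ethyl or acetyl on this nitrogen would fare the same remains open. The compounds shown also cannot tell whether losing the hydrogen or gaining the methyl matters more.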